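The source may hold more compounds than are shown below. What is called first, only, known or untested is meant among the compounds shown, and "the series" means these compounds.

Measured in a functional assay on MCF7 cells (Homo sapiens) for antiproliferative activity, read by CellTiter-Glo, with a stated time of 5 days; on this read-out lower numbers stand for stronger inhibition and higher numbers for weaker inhibition:
- compound 1 `CC/C(=C(/c1ccc(/C=C/C(=O)O)cc1)c1ccc2c(cnn2C)c1)c1ccccc1`: 300 nM
- compound 2 `CC/C(=C(/c1ccc(/C=C/C(=O)O)cc1)c1ccn2nccc2c1)c1ccccc1`: > 500 nM (a limit, not a number)
- compound 3 `CC/C(=C(/c1ccc(/C=C/C(=O)O)cc1)c1ccn2ccnc2c1)c1ccccc1`: > 500 nM (a limit, not a number)

Compound 3 has no exact number of its own: its result, > 500 nM, is a limit. This is the limit of > 500 nM in this assay, at which 2 of the 3 values shown sit.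

Compound 4 `CC/C(=C(/c1ccc(/C=C/C(=O)O)cc1)c1ccn2nncc2c1)c1ccccc1` makes one structural change to compound 3: a group of 9 heavy atoms (6 carbon, 3 nitrogen; one five-membered aromatic ring with 3 hetero atoms, one six-membered aromatic ring with 1 hetero atom) in place of a group of 9 heavy atoms (7 carbon, 2 nitrogen; one five-membered aromatic ring with 2 hetero atoms, one six-membered aromatic ring with 1 hetero atom), on a double-bonded chain carbon bound to an aromatic carbon and a double-bonded chain carbon.

Three measured steps exchange a group at this same place. Two of them start from compound 1: an at least 1.6-fold higher number from compound 1 to compound 2 (0.22 log units; that floor lies within the scatter), and an at least 1.6-fold higher number from compound 1 to compound 3 (0.22 log units; that floor lies within the scatter). The third is the closest comparison: it joins two groups of the same size. It gives no size: a step that the two limits leave unreadable from compound 2 to compound 3. None of the three therefore shows a step beyond the scatter, and none points to a direction for the new exchange.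

Compound 4 is therefore expected to remain close to compound 3, and it may also be reported only as a limit. The expected step, no larger than the scatter can account for, is a step that the limit leaves unreadable from compound 3 to compound 4. The estimate for compound 4 is 800 nM, with an expected range of 400 nM to 2000 nM.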

Compound 4, half-maximal inhibitory concentration: > 500 nM
Compound 4: no number, only a limit; the forecaster's own chance of this, stated with the estimate: 85%; the middle value lies beyond the limit too.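

In this assay compound 4 gives > 500 nM, which is a limit and not a number. Adding a third hetero atom to the five-membered aromatic ring therefore produces no measurable value, and this is the third group with a six-membered aromatic ring with 1 hetero atom to end this way: the limit of > 500 nM in this assay, at which 3 of the 4 values shown sit. The only step that can be read is an at least 1.6-fold higher number from compound 1 to compound 4 (0.22 log units; that floor lies within the scatter), while the steps joining compound 4 to compound 2 and compound 3 cannot be read, so these results establish no real difference at this place.

From the compounds shown here alone, how far compound 2, compound 3 and compound 4 lie beyond the limit, and whether they differ from one another, remains open. Also open, going by these compounds, is whether an amine or a methyl group on the entering group would give a measurable number.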